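Methyl on the thiophene ring: expectation for compound 4

A few compounds are considered here, and "the series" means these few. Any claim that something is new, unique, unknown or untested is made for them only; others in the source may bear on it.

Measured so far:
compound 1 `C=C(Br)C(=O)Nc1ccc2c(c1)/C(=C/c1cccs1)C(=O)N2` gives 1700 nM
compound 2 `C=C(Br)C(=O)Nc1ccc2c(c1)/C(=C\c1ccsc1)C(=O)N2` gives 2600 nM
compound 3 `C=C(Br)C(=O)Nc1ccc2c(c1)/C(=C\c1cccs1)C(=O)N2` gives 1800 nM

All three numbers come from a functional assay on HeLa cells (Homo sapiens) for antiproliferative activity, read by MTT assay, with a stated time of 72 h; on this read-out higher numbers stand for weaker inhibition and lower numbers for stronger inhibition. Compound 1 gives the smallest of the three numbers shown, with compound 3 nearest and compound 2 furthest; neither gap is beyond the scatter. From compound 1 to compound 3 the step is a 1.1-fold higher number from compound 1 to compound 3 (0.02 log units; within the scatter), which rests on (the fact that compounds 1 and 3 differ only in the configuration as drawn). From compound 2 to compound 3 the step is a 1.4-fold lower number from compound 2 to compound 3 (0.16 log units; within the scatter).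

Compound 4 `C=C(Br)C(=O)Nc1ccc2c(c1)/C(=C/c1ccc(C)s1)C(=O)N2` has not yet been measured in this assay. It differs from compound 1 by methyl in place of hydrogen on an aromatic carbon, which read one bond further out is thiophen-2-yl to 5-methylthiophen-2-yl. Among the compounds with values here, no measured step adds a methyl; the two steps at hand, the drawn configuration and the thiophene attachment point, both stay within the scatter, so the shared core tolerates small changes at this end without a shift in the number. The expected step from compound 1 to compound 4 is therefore no change at the digits printed from compound 1 to compound 4 (within the scatter), no direction beyond the scatter. Compound 4 is estimated at 1700 nM, expected between 800 nM and 3600 nM.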

Compound 4, half-maximal inhibitory concentration: 1600 nM
For compound 4 the middle estimate is 1.1-fold (0.03 log units) above the measured one; measured number inside the range.
By their numbers in this assay, from the lowest: compounds 4, 1, 3 and 2 (each within the scatter of the next).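

In this assay, the change from thiophen-2-yl to 5-methylthiophen-2-yl gives a 1.1-fold lower number from compound 1 to compound 4 (0.03 log units; within the scatter). Of the steps shown, this is the only one that adds a heavy atom rather than changing the thiophene attachment point or the drawn configuration, and it shows that a methyl next to the ring sulfur, two ring bonds from the ring atom that bears a large group, leaves the number within the scatter. Nothing at hand gives a measured reason for this outcome.

From the compounds shown here alone, how far this tolerance extends remains open: an ethyl, a phenyl, an aminomethyl or a carboxylic acid at the same position could read differently. The compounds shown also leave open whether the methyl would give the same reading on the thiophen-3-yl of compound 2 or in the drawn configuration of compound 3.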